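From 2-fluorophenyl to 3-fluorophenyl: what compound 4 may show

This account rests on a few compounds, and the source may have more. Where it says the series, first, only, none or still open, it means among the compounds named here.

Values in an ADME assay on THP-1 cells (Homo sapiens) for cytotoxicity, read by flow cytometry and propidium iodide staining, with a stated time of 72 h (a lower number here means a stronger inhibitor, a higher number a weaker inhibitor), stand as follows:
- compound 1 `CC(=O)Nc1ccc2oc(-c3ccccc3)cc(=O)c2c1` gives 97000 nM
- compound 2 `COc1cccc(-c2cc(=O)c3cc(NC(C)=O)ccc3o2)c1` gives 10000 nM
- compound 3 `CC(=O)Nc1ccc2oc(-c3ccccc3F)cc(=O)c2c1` gives > 125000 nM

Compound 3 has no number on this scale, and its entry of > 125000 nM is a limit of the assay. The next compound to be tested is compound 4 `CC(=O)Nc1ccc2oc(-c3cccc(F)c3)cc(=O)c2c1`, which has the same atoms as compound 3 joined differently: 3-fluorophenyl in place of 2-fluorophenyl on an aromatic carbon is the whole change.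

Going by the values given here, two measured steps bear on it. Fluoro in place of hydrogen on an aromatic carbon gave an at least 1.2-fold higher number from compound 1 to compound 3 (0.11 log units; that floor lies within the scatter), a floor that lies within the scatter. Methoxy in place of hydrogen on an aromatic carbon gave a 9.7-fold lower number from compound 1 to compound 2 (0.99 log units; beyond the scatter), which lies beyond the scatter, and that methoxy stands on the ring carbon that holds fluoro in compound 4. Compound 2 at 10000 nM is the only sign of a lower number, and since it holds methoxy rather than fluoro, only part of that step is expected to carry over. The expected change is an at least 2.5-fold lower number from compound 3 to compound 4 (0.39 log units; beyond the scatter) and this remains an estimate resting on few compounds. For compound 4 the estimated value is 50000 nM with an expected range of 15000 nM to 125000 nM.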

Compound 4, half-maximal inhibitory concentration: > 125000 nM
Compound 4 was reported as a limit (the forecaster's own chance of this, stated with the estimate: 25%); middle value at least 2.5-fold (0.39 log units) away from the limit.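

In this assay, fluoro in place of methoxy on the same ring carbon gave an at least 12-fold higher number from compound 2 to compound 4 (1.09 log units; beyond the scatter), so among the compounds shown, the lower number at this position appears only with methoxy. Fluoro in place of hydrogen gave an at least 1.2-fold higher number from compound 1 to compound 4 (0.11 log units; that floor lies within the scatter), a floor that lies within the scatter, so moving fluoro to this position did not bring a lower number into view. Compound 3 and compound 4 both stand at a limit of the assay rather than at a number, so the step between them cannot be read: the limit of > 125000 nM in this assay, at which 2 of the 4 values shown sit.

Going by these compounds, it remains open whether the lower number of compound 2 depends on the oxygen of methoxy or on the group as a whole, which a hydroxyl, an ethoxy or a methyl on that ring carbon would help to separate. Also open, on these data alone, is whether methoxy would give a similar step on the ring carbon that holds fluoro in compound 3, and how far compound 3 and compound 4 lie from each other beyond the limit.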